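A few compounds are considered here, and "the series" means these few. Any claim that something is new, unique, unknown or untested is made for them only; others in the source may bear on it.

In a functional assay on the whole organism (strain Wistar) for inhibition, with Rattus norvegicus as the target, read by paw edema, with stated times of 1 h and 3 h, at a dose of 100 mg/kg by the oral route (on this read-out lower numbers stand for less inhibition and higher numbers for more inhibition at the one dose given (going by the name of the read-out)), compound 1 `COc1ccc2c(c1)c(CC(=O)OCOC(=O)C(C)(C)C)c(C)n2C(=O)c1ccc(Cl)cc1` gives 48.4%. Compound 2 `COc1ccc2c(c1)c(CC(=O)OCCOC(C)=O)c(C)n2C(=O)c1ccc(Cl)cc1` gives 44.4% in this assay, and this number stands within the scatter of compound 1's, since the step of a number 4 percentage points lower from compound 1 to compound 2 (within the scatter) is within the scatter. Compound 3 `COc1ccc2c(c1)c(CC(=O)OCc1oc(=O)oc1C)c(C)n2C(=O)c1ccc(Cl)cc1` differs from compound 2 by a group of 7 heavy atoms (4 carbon, 3 oxygen; one five-membered aromatic ring with 2 hetero atoms) in place of a group of 5 heavy atoms (3 carbon, 2 oxygen; no ring), on a saturated chain carbon bound to an oxygen next to a carbonyl group. Going by the values given here, the only measured step at this position, that from compound 1 to compound 2, was within the scatter, so the step of a number 0.6 percentage points higher from compound 2 to compound 3 (within the scatter) is expected to be none beyond the scatter. Compound 3 is therefore estimated at 45% in this assay, in the range 32% to 58%.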

Compound 3, a percentage reported as inhibition, in the whole organism at one dose (the size of the read-out at that dose, not a potency) in the Rattus norvegicus assay: 12.1%
Beside the measured number, compound 3's estimate is 32.9 percentage points above it; the whole stated range lies above it.
By their numbers in the Rattus norvegicus assay, from the lowest: compound 3; then compounds 2 and 1 (each within the scatter of the next).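

In the Rattus norvegicus assay this place on the saturated chain carbon, where the earlier exchange had stayed within the scatter, proves sensitive to the group that enters, with a number 32.3 percentage points lower from compound 2 to compound 3 (beyond the scatter) and a number 36.3 percentage points lower from compound 1 to compound 3 (beyond the scatter) when the five-membered aromatic ring arrives. In a physicochemical assay for solubility, read by HPLC, with a stated time of 4 h, at pH 9 (on this read-out higher numbers stand for higher solubility and lower numbers for lower solubility), compound 2 gives 0.111 ug/mL and compound 3 gives 0.0638 ug/mL with a 1.7-fold lower number from compound 2 to compound 3 (0.24 log units; within the scatter) so that read-out does not separate the two. Nothing available explains the fall in inhibition. The compounds shown leave open how a free carboxylic acid, or a longer chain ending in an amine, would read at this place in the Rattus norvegicus assay.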